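The source may hold more compounds than are shown below. What is called first, only, known or untested is meant among the compounds shown, and "the series" means these compounds.

Compound 1 (`CC[C@@H](Nc1c(C#N)c(-c2ccc(-c3ccccc3F)cc2)nc2cnccc12)C(N)=O`) is the point of departure. In a physicochemical assay for lipophilicity, read by HPLC, at pH 7.5 (on this read-out lower numbers stand for lower lipophilicity and higher numbers for higher lipophilicity), compound 1 gives 2.7, the lower of the two numbers recorded so far. Within the data shown here, its only measured companion is compound 2 (`CCOc1ccccc1-c1ccc(-c2nc3cnccc3c(N[C@H](CC)C(=O)N(C)C)c2C#N)cc1`), which in this assay gives 3.7, a gap beyond the usual scatter; compound 2 differs from compound 1 in several places at once, so no single change accounts for that gap.

Compound 3 (`CC[C@@H](Nc1c(C#N)c(-c2ccc(-c3ccccc3NC)cc2)nc2cnccc12)C(N)=O`) has not been measured. It is compound 1 with methylamino in place of fluoro on an aromatic carbon of a six-membered aromatic ring of carbon only. The change brings in one hydrogen-bond donor and one hydrogen-bond acceptor where fluoro carried none.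

Among the measured compounds shown here, no measured pair shows this exchange, so the expectation rests on compound 1 alone and on the nature of the change. The step from compound 1 to compound 3 in this assay is expected to be a modest decrease, a number 0.40 log units lower from compound 1 to compound 3 (beyond the scatter), somewhat beyond the scatter. Compound 3 is therefore estimated at 2.3 in this assay, within a range from 1.8 to 2.8.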

Compound 3, distribution coefficient: 2.5
Beside the measured number, compound 3's estimate is 0.20 log units below it; low and high end bracket the measured number.
By their numbers in this assay, from the lowest: compounds 3 and 1 (each within the scatter of the next); then compound 2.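

In this assay the exchange of fluoro for methylamino reads as a number 0.20 log units lower from compound 1 to compound 3 (within the scatter). Among these compounds, this is the first step that isolates a single place, which compounds 1 and 2, differing in several places at once, could not do. On an aromatic carbon ortho to a large group, then, methylamino, with its hydrogen-bond donor, its hydrogen-bond acceptor and its extra heavy atom, cannot be told apart from fluoro on this read-out, although this rests on one pair only. No measurement at hand explains why the two groups read so closely.

Going by these compounds, it remains open whether other groups at this place, such as dimethylamino, an amine with a longer chain or a carboxylic acid, would also stay within the scatter of compound 1, or whether they would move the number clearly. Among the compounds shown here, also open is how much of the higher number of compound 2 belongs to its ethoxy group and how much to its changed amide, as no compound here separates the two.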